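Cyclopropyl to 4-Hydroxybenzyl on an Amine of Unknown Reach

This account rests on a few compounds, and the source may have more. Where it says the series, first, only, none or still open, it means among the compounds named here.

Compound 1 `CNCc1c(OC)cc(Oc2cccc(Nc3ccccc3)c2)cc1OC` and compound 2 `COc1cc(Oc2cccc(Nc3ccccc3)c2)cc(OC)c1CNC1CC1` share one core and differ only at the amine nitrogen, where a cyclopropyl replaces a methyl. In a functional assay on HCT-116 cells (Homo sapiens) for inhibition, read by MTT assay, with a stated time of 72 h (on this read-out lower numbers stand for stronger inhibition and higher numbers for weaker inhibition), compound 1 gives only a limit, > 20000 nM. In this assay compound 2 likewise gives only a limit, > 20000 nM. The step that the two limits leave unreadable from compound 1 to compound 2 is therefore not readable in size, which the limit of > 20000 nM in this assay, at which 2 of the 2 values shown sit, shows. Compound 3 `COc1cc(Oc2cccc(Nc3ccccc3)c2)cc(OC)c1CNCc1ccc(O)cc1` arises from compound 2 by 4-hydroxybenzyl in place of cyclopropyl on an amine nitrogen. Among the compounds with values here, no measured step bears on this change with a readable size, so nothing in the numbers points in either direction beyond the scatter, and compound 2 stands at a limit rather than at a value. Compound 3 is accordingly expected to remain weak in this assay, estimated at 20000 nM with a range from 5000 nM to 60000 nM. The expected step is a number no higher from compound 2 to compound 3 (the limit leaves the size open).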

Compound 3, half-maximal inhibitory concentration: 3360 nM
Beside the measured number, compound 3's estimate is 6.0-fold (0.77 log units) above it; measured number below the stated range.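

With 4-hydroxybenzyl on this amine nitrogen, the shared core reaches a readable number in this assay for the first time among the compounds shown, and the change in place of cyclopropyl gives an at least 5.9-fold lower number from compound 2 to compound 3 (0.77 log units; beyond the scatter). Set against the methyl amine, the result is an at least 5.9-fold lower number from compound 1 to compound 3 (0.77 log units; beyond the scatter), so the substituent on this nitrogen can shift the read-out, which the unreadable step between the two earlier compounds could not show. Both sizes remain lower bounds because the two earlier compounds stand at a limit: the limit of > 20000 nM in this assay, at which 2 of the 3 values shown sit.

The compounds shown leave open whether the step goes with the hydroxyl or with the aromatic ring of the 4-hydroxybenzyl, a question that a plain benzyl or a 4-methoxybenzyl on the same nitrogen would address. On these data alone, how a longer chain between that nitrogen and the ring would read also stays open.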